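A few compounds are considered here, and "the series" means these few. Any claim that something is new, unique, unknown or untested is made for them only; others in the source may bear on it.

Measured so far:
compound 1 `CCOC(=O)COc1ccc2c(=O)c(-c3ccc(O)cc3)coc2c1` with 130 nM in an assay (Cricetulus griseus) for inhibition of aldehyde dehydrogenase, mitochondrial (Homo sapiens); a lower number here means a stronger inhibitor, a higher number a weaker inhibitor
compound 2 `O=C(O)CCCCCCCOc1ccc2c(=O)c(-c3ccc(O)cc3)coc2c1` with 40 nM in this assay

Among the compounds with values here, compound 2 holds the lowest of the two numbers; the only step known is a 3.3-fold lower number from compound 1 to compound 2 (0.51 log units; beyond the scatter), a modest gain with a longer chain. Compound 3 `O=c1c(-c2ccc(O)cc2)coc2cc(OCCCCCCCCCCCCO)ccc12` differs from compound 2 by 5-hydroxypentyl in place of carboxy on a saturated chain carbon, seven bonds along the chain from an oxygen on an aromatic ring. Within the data shown here, no measured step covers a swap of a carboxy for a hydroxyl at the end of such a chain, and the chain grows further; only the direction of the earlier step is informative. A change within the scatter, or a small one either way, is therefore expected: a 1.3-fold higher number from compound 2 to compound 3 (0.10 log units; within the scatter). Compound 3 is estimated at 50 nM, in the range 15 nM to 160 nM.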

Compound 3, half-maximal inhibitory concentration: 1700 nM
The estimate for compound 3 lay 34-fold (1.53 log units) below the measured number; measured number above the stated range.
By their numbers in this assay, from the lowest: compound 2; then compound 1; then compound 3.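

Swapping carboxy for 5-hydroxypentyl gives a 43-fold higher number from compound 2 to compound 3 (1.63 log units; beyond the scatter), a far larger shift than the modest 3.3-fold lower number from compound 1 to compound 2 (0.51 log units; beyond the scatter), so the far end of this chain is not indifferent to change. The swap removes the carboxy and lengthens the chain in a single step, so the two changes cannot be told apart here. Nothing available explains the loss of inhibition.

Going by these compounds, it remains open whether the carboxy or the chain length matters more. An amine or a primary amide at the chain end could also behave quite differently.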